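The compounds below may be only part of what the source reports. "The series", "measured", "known", "first", "only" and "open" are said of these compounds alone.

Compound 1, `COc1cccc(OC)c1C(=O)OC1CCN(C)CC1`, was tested in a functional assay on the whole organism with Mus musculus as the target (a higher number here means a more potent compound, by a factor of ten per unit of this negative logarithm, a lower number a less potent compound), where compound 1 gives 0.63. That is the lowest of the two numbers at hand; the nearest is compound 2, `COc1ccccc1C(=O)OC1CCN(C)CC1`, which in this assay gives 1.43. Among the measured compounds shown here, the one measured step, hydrogen in place of methoxy on an aromatic carbon, was a number 0.80 log units higher from compound 1 to compound 2 (beyond the scatter). Compound 3, `COc1cc(OC)c(C(=O)OC2CCN(C)CC2)c(OC)c1`, differs from compound 1 by methoxy in place of hydrogen on an aromatic carbon. The step from compound 1 to compound 2 bears on this change only in reverse: taking one methoxy away raised the number, so adding a third methoxy, placed meta to two methoxy groups and para to a large group, is expected to move it the other way, though the reverse of that step need not be of equal size. The estimate for compound 3 is therefore 0.1, with a range of -0.6 to 0.8, a step of a number 0.53 log units lower from compound 1 to compound 3 (beyond the scatter) expected.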

Compound 3, logarithm of the reciprocal of the active concentration, log(1/C): 1.47
Compound 3: the middle estimate sits 1.37 log units below what was measured, and the stated range ends below it.
By their numbers in this assay, from the lowest: compound 1; then compounds 2 and 3 (each within the scatter of the next).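

In this assay, among the compounds shown here, methoxy in place of hydrogen at this place, meta to two methoxy groups and para to a large group, was a number 0.84 log units higher from compound 1 to compound 3 (beyond the scatter), so the change raises the number, as the only earlier step did not suggest. Taking a methoxy away was also a number 0.80 log units higher from compound 1 to compound 2 (beyond the scatter), so among these three compounds, adding and removing a methoxy on the core of compound 1 both raise the number, and the effect of the group depends on where it sits or on which others stand with it. Nothing at hand explains this rise.

As far as these compounds go, what stays open is whether this place favours methoxy in particular, or whether a hydroxyl, a chlorine or an amine there would also raise the number. The compounds shown also leave open how a longer alkoxy chain would behave at this place.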